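Working notes: from 4-chlorobenzyl to 4-fluorobenzyl

The source may report more compounds than this note shows. Statements on the series, on what has been measured and on what is new or still open speak of the compounds shown alone.

Measured in an ADME assay on cells (Astrocyte, Homo sapiens) for cytotoxicity, read by WST assay, with a stated time of 72 h; a lower number here means a stronger inhibitor, a higher number a weaker inhibitor:
- Compound 1 `O=C(Nc1ccc(C(F)(F)F)cc1)Nc1cc2ncncc2cc1OCc1cccc(F)c1`: 8900 nM
- Compound 2 `O=C(Nc1cc2ncncc2cc1OCc1ccc(Cl)cc1)Nc1cccc2ccccc12`: > 10000 nM (a limit, not a number)
- Compound 3 `O=C(Nc1ccccc1F)Nc1cc2ncncc2cc1OCc1ccccc1`: > 10000 nM (a limit, not a number)

Compound 2 has only a limit and no number: the limit of > 10000 nM in this assay, at which 2 of the 3 values shown sit. Compound 4 `O=C(Nc1cc2ncncc2cc1OCc1ccc(F)cc1)Nc1cccc2ccccc12` is the next to be read against it. The change is fluoro in place of chloro on an aromatic carbon, para to a large group. Among the measured compounds shown here, no measured pair differs in one place only, so the size of this swap is untested. No shift beyond the scatter is expected, and the estimated step is a step that the limit leaves unreadable from compound 2 to compound 4. For the measured compounds named here, compound 1 gives 8900 nM, the only number available as a guide. For compound 4 the expected value is 12000 nM, with an estimated range of 6000 nM to 25000 nM.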

Compound 4, half-maximal inhibitory concentration: 8500 nM
The estimate for compound 4 lay 1.4-fold (0.15 log units) above the measured number, within the range that was stated.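

The swap from 4-chlorobenzyl to 4-fluorobenzyl gives the series its first comparison in one place: in this assay it amounts to an at least 1.1-fold lower number from compound 2 to compound 4 (0.07 log units; that floor lies within the scatter). The value of compound 2, > 10000 nM, is a limit and not a number. Compound 4 supplies a measured number for this position, 8500 nM, so a halogen here is compatible with a value that can be read.

As far as these compounds go, how far the true step lies past its floor remains open. Also open, from the compounds shown here alone, is whether an amine or a carboxylic acid in the same place would move the number beyond the scatter.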